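A few compounds are considered here, and "the series" means these few. Any claim that something is new, unique, unknown or untested is made for them only; others in the source may bear on it.

Measured so far in an ADME assay on cells (Mus musculus, strain BALB/c) for cytotoxicity, read by MTT assay, with a stated time of 24 h; on this read-out higher numbers stand for lower toxicity in this test and lower numbers for higher toxicity in this test:
compound 1 `COc1cc(-c2nnc(SCc3ccccc3F)o2)ccc1O` — 474000 nM
compound 2 `COc1cc(-c2nnc(SCc3cccc(Cl)c3)o2)ccc1O` — 470000 nM

Compound 2 stands lowest of the two numbers, though its nearest neighbour is compound 1, and the only shown step, a 1.0-fold lower number from compound 1 to compound 2 (0.00 log units; within the scatter), lies within the scatter, so no order between the two can be claimed.

Compound 3 `COc1cc(-c2nnc(SCc3ccc(F)cc3)o2)ccc1O` is the next member of the series and remains to be measured. Its difference from compound 2 is 4-fluorophenyl in place of 3-chlorophenyl on a saturated chain carbon bound to a sulfur. Among the compounds with values here, the one measured step that bears on this kind of change, a swap of the substituted phenyl on the saturated chain carbon bound to a sulfur, is a 1.0-fold lower number from compound 1 to compound 2 (0.00 log units; within the scatter), which produced no movement beyond the scatter. Within the data shown here, no other step is available. The expectation for compound 3 is therefore a step of no change at the digits printed from compound 2 to compound 3 (within the scatter), essentially none beyond the scatter, in this assay. Compound 3 is estimated at 470000 nM, with a range from 235000 nM to 940000 nM.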

Compound 3, half-maximal cytotoxic concentration: 685000 nM
Compound 3: the middle estimate sits 1.5-fold (0.16 log units) below what was measured; the measured number falls inside the stated range.
By their numbers in this assay, from the lowest: compounds 2, 1 and 3 (each within the scatter of the next).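

In this assay, within the data shown here, moving the fluorine on the phenyl gives the first comparison of the same halogen at two ring positions, and it stays within the scatter (a 1.4-fold higher number from compound 1 to compound 3 (0.16 log units; within the scatter)). Exchanging 3-chlorophenyl for 4-fluorophenyl alters both the halogen and its ring position, yet this also stays within the scatter (a 1.5-fold higher number from compound 2 to compound 3 (0.16 log units; within the scatter)), so all three compounds remain unresolved from one another and no substituent order can be drawn. No measured evidence on the origin of these small differences is available.

All three compounds carry a single halogen on the phenyl, so the range of groups compared at this place is narrow. Open, from the compounds shown here alone, is whether a phenyl bearing a carboxylic acid or an amine, or a longer chain in place of the phenyl, would move the number beyond the scatter in this assay.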